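Three level compounds and one chain change

The source may report more compounds than this note shows. Statements on the series, on what has been measured and on what is new or still open speak of the compounds shown alone.

compound 1 `O=S(=O)(NCCNc1nccc(-c2c(-c3cccc(F)c3)nc3sccn23)n1)c1ccc(F)cc1` gives 9450 nM
compound 2 `O=S(=O)(NCCNc1nccc(-c2c(-c3cccc(F)c3)nc3sccn23)n1)c1ccc(C(F)(F)F)cc1` gives 8450 nM
compound 3 `O=C(NCCNc1nccc(-c2c(-c3cccc(F)c3)nc3sccn23)n1)c1ccc(C(F)(F)F)cc1` gives 9260 nM

All three values come from a functional assay on SK-MEL-28 cells (Homo sapiens) for cytotoxicity, read by MTT assay (on this read-out lower numbers stand for stronger inhibition and higher numbers for weaker inhibition), and lie within the scatter of one another, so compound 1 stands level with compound 2 and compound 3 on these numbers.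

The next compound to be tested is compound 4 `O=C(NCCCNc1nccc(-c2c(-c3cccc(F)c3)nc3sccn23)n1)c1ccc(Cl)cc1` in the same assay. The change is (((4-chlorophenyl)carbonyl)amino)methyl in place of ((4-fluorophenyl)sulfonyl)amino on a saturated chain carbon, two bonds along the chain from a nitrogen on an aromatic ring and amounts to (((4-chlorophenyl)carbonyl)amino)methyl in place of ((4-fluorophenyl)sulfonyl)amino on a saturated chain carbon, two bonds along the chain from a nitrogen on an aromatic ring.

Among the compounds with values here, two measured steps bear on this. Putting trifluoromethyl in place of fluoro on an aromatic carbon gave a 1.1-fold lower number from compound 1 to compound 2 (0.05 log units; within the scatter) on this read-out. Putting (4-(trifluoromethyl)phenyl)carbonyl in place of (4-fluorophenyl)sulfonyl on an amine nitrogen gave a 1.0-fold lower number from compound 1 to compound 3 (0.01 log units; within the scatter) on this read-out. Neither step moved the number beyond the scatter. Within the data shown here, no measured compound tests the added methyl part on the chain or the chloro group, so this expectation carries real uncertainty.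

No step beyond the scatter is expected. The estimated step is a 1.2-fold lower number from compound 1 to compound 4 (0.07 log units; within the scatter) in this assay on present evidence. The estimate for compound 4 is 8000 nM with an expected range from 3000 nM to 16000 nM on this read-out.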

Compound 4, half-maximal inhibitory concentration: > 20000 nM
Compound 4 gave a limit, no number; the forecaster's own chance of this, stated with the estimate: 10%; middle value at least 2.5-fold (0.39 log units) away from the limit.
By their numbers in this assay, from the lowest: compounds 2, 3 and 1 (each within the scatter of the next). At a limit, above all of these: compound 4.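

In this assay, within the data shown here, the change to compound 4 gives an at least 2.1-fold higher number from compound 1 to compound 4 (0.32 log units; beyond the scatter), the first step in this set to pass the scatter, so this stretch of the chain is not as indifferent to change as the earlier compounds suggested. Compound 4 gives a limit of the assay, not an exact number: the limit of > 20000 nM in this assay, at which 1 of the 4 values shown sits. Swapping the sulfonyl link for a carbonyl link, together with trifluoromethyl for fluoro, gave only a 1.0-fold lower number from compound 1 to compound 3 (0.01 log units; within the scatter), whereas the step to compound 4 also brings in the added methyl part on the chain and the chloro group, and only with these does the reading leave the scatter.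

The compounds shown do not separate the added methyl part on the chain from the chloro group, as both enter together in compound 4, and the carbonyl link comes with them, so the step cannot be assigned to any one of these parts. Also open, from the compounds shown here alone, is how a still longer chain, or a nitrile or a methoxy group in place of the chloro group, would read in this assay.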